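A Second Methoxy on the Aromatic Ring

The source may hold more compounds than are shown below. What is called first, only, known or untested is meant among the compounds shown, and "the series" means these compounds.

In a functional assay on K562 cells (Homo sapiens) for antiproliferative activity, read by MTT assay, with a stated time of 48 h (on this read-out lower numbers stand for stronger inhibition of growth and higher numbers for weaker inhibition of growth), compound 1 `COc1ccc(N(C)c2nc(Cl)nc3c2ncn3C)cc1` gives 2300 nM. Compound 2 `COc1ccc(Cn2cnc3c(N(C)c4ccc(OC)cc4)nc(Cl)nc32)cc1` gives only a limit of the assay, > 100000 nM. Compound 3 `COc1ccc(N(C)c2nc(Cl)nc3c2ncn3Cc2ccc(OC)c(OC)c2)cc1` differs from it by methoxy in place of hydrogen on an aromatic carbon, 4-methoxyphenyl to 3,4-dimethoxyphenyl (methoxy in place of hydrogen on an aromatic carbon). Going by the values given here, the one step bearing on this is large, an at least 43-fold higher number from compound 1 to compound 2 (1.63 log units; beyond the scatter), for 4-methoxyphenyl in place of hydrogen on a saturated chain carbon bound to an aromatic nitrogen, and compound 3 keeps that group. No step beyond the scatter is therefore expected in this assay, in either direction. The estimated change is a number no higher from compound 2 to compound 3 (the limit leaves the size open). Compound 3 is expected at 100000 nM, within 30000 nM to 300000 nM.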

Compound 3, concentration for 50% growth inhibition: 27000 nM
For compound 3 the middle estimate is 3.7-fold (0.57 log units) above the measured one; measured number below the stated range.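

In this assay, going by these compounds alone, the added methoxy gives an at least 3.7-fold lower number from compound 2 to compound 3 (0.56 log units; beyond the scatter) and thus shows that this aromatic carbon can move the read-out, which the earlier compounds could not show. The 3,4-dimethoxyphenyl group still gives a 12-fold higher number from compound 1 to compound 3 (1.07 log units; beyond the scatter) so the added ring methoxy reduces the loss of growth inhibition but does not remove it. The full size of the methoxy step stays open because compound 2 stands at a limit of the assay: the limit of > 100000 nM in this assay, at which 1 of the 3 values shown sits.

The compounds shown leave open whether a hydroxyl, a chlorine or an amine on this aromatic carbon would move the number further.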